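A few compounds are considered here, and "the series" means these few. Any claim that something is new, unique, unknown or untested is made for them only; others in the source may bear on it.

The series shares one boronate core carrying a guanidine-bearing side chain and an amide-linked biphenyl group. Compound 1 `CC1(C)C2CC1[C@]1(C)OB([C@H](CCCN=C(N)N)NC(=O)c3ccc(-c4ccccc4)cc3)O[C@@H]1C2` gives 33 nM in an assay on isolated protein for inhibition of serine protease 1 (Homo sapiens); on this read-out higher numbers stand for weaker inhibition and lower numbers for stronger inhibition. Compound 2 `CC(C)(C)OC(=O)Nc1cccc(-c2cccc(C(=O)N[C@@H](CCCN=C(N)N)B3O[C@@H]4CC5CC(C5(C)C)[C@]4(C)O3)c2)c1` gives 35 nM in this assay. Compound 3 `CC1(C)C2CC1[C@]1(C)OB([C@H](CCCN=C(N)N)NC(=O)c3cccc(-c4cccc(NS(C)(=O)=O)c4)c3)O[C@@H]1C2` gives 3.8 nM in this assay and therefore stands lowest of the three, with compound 1 the nearest and compound 2 the furthest, both beyond the scatter. For the measured compounds named here, the single measured step that alters one group, a 9.2-fold lower number from compound 2 to compound 3 (0.96 log units; beyond the scatter), shows that the substituent on the outer ring moves the number substantially. Compound 4 `CC1(C)C2CC1[C@]1(C)OB([C@H](CCCN=C(N)N)NC(=O)c3cccc(-c4ccccc4)c3)O[C@@H]1C2` has not yet been measured in this assay; it differs from compound 3 by hydrogen in place of methanesulfonamido on an aromatic carbon. Going by the values given here, no measured step removes this group outright. Compound 1, which also carries an unsubstituted outer phenyl ring, gives 33 nM, and compound 2, whose outer ring carries a tert-butoxycarbonyl amino group instead, gives 35 nM; both lie beyond the scatter from compound 3. The expected step is therefore an upward one, a 6.6-fold higher number from compound 3 to compound 4 (0.82 log units; beyond the scatter), since the two compounds lacking the methanesulfonamido group both sit far from compound 3. Compound 4 is estimated at 25 nM, with a range from 8 nM to 80 nM.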

Compound 4, inhibition constant: 7.4 nM
Compound 4: middle estimate off by 3.4-fold (0.53 log units), on the high side, and the stated range ends above it.
By their numbers in this assay, from the lowest: compounds 3 and 4 (each within the scatter of the next); then compounds 1 and 2 (each within the scatter of the next).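

Taking methanesulfonamido off the outer ring to leave a plain phenyl gives a 1.9-fold higher number from compound 3 to compound 4 (0.29 log units; within the scatter) in this assay, so at this aromatic carbon the group shows no change that can be told from the scatter, and the low number of compound 3 does not depend on it. The step from compound 2 to compound 3 had suggested that methanesulfonamido lowered the number, but hydrogen in place of (tert-butoxycarbonyl)amino at the same carbon gives a 4.7-fold lower number from compound 2 to compound 4 (0.67 log units; beyond the scatter), which shows that the unsubstituted ring does this as well and that compound 2 is the one that stands apart from this pair. The unsubstituted compounds also separate a second variable, since 3-phenylphenyl in place of 4-phenylphenyl on the carbonyl carbon gives a 4.5-fold lower number from compound 1 to compound 4 (0.65 log units; beyond the scatter), so the way the two rings are joined moves the number even with no substituent on the outer ring.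

Nothing shown explains why these numbers fall as they do. The compounds shown leave open how a primary amine or a carboxylic acid on the same aromatic carbon would compare, and whether methanesulfonamido would matter on the 4-phenylphenyl arrangement of compound 1.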